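This account rests on a few compounds, and the source may have more. Where it says the series, first, only, none or still open, it means among the compounds named here.

Measured compounds: compound 1, `CC1=C(C(=O)OCC(C)C)C(c2ccco2)NC(=O)N1C`, giving 4% in an assay on membranes from HEK293 cells for displacement of a labelled ligand from adenosine receptor A2b (Homo sapiens), read by scintillation counting, with a stated time of 30 min, tested at 1 uM; a higher number here means more inhibition at the concentration tested (going by the name of the read-out), a lower number less inhibition; compound 2, `CC1=C(C(=O)OC(C)C)C(c2ccoc2)NC(=O)N1C`, giving 37% in this assay.

Among the compounds with values here, compound 2 stands highest of the two values, and the only other value, that of compound 1, lies lower by a margin beyond the usual scatter. Compound 3, `CC1=C(C(=O)OCC(C)C)C(c2ccoc2)NC(=O)N1C`, differs from compound 2 by isobutyl in place of isopropyl on an oxygen next to a carbonyl group. Within the data shown here, no measured pair differs in this way alone, so the data give no direct guide to the step in this assay; a modest shift in either direction, or none beyond the scatter, seems plausible. Compound 3 is therefore expected to show about a number 7 percentage points lower from compound 2 to compound 3 (within the scatter), an estimated 30% with a range from 5% to 60%.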

Compound 3, a percentage reported as inhibition, at one concentration (the size of the read-out at that concentration, not a potency): 1%
The estimate for compound 3 lay 29 percentage points above the measured number, outside the stated range (below it).
By their numbers in this assay, from the lowest: compounds 3 and 1 (each within the scatter of the next); then compound 2.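

In this assay, isobutyl in place of isopropyl on an oxygen next to a carbonyl group gives a number 36 percentage points lower from compound 2 to compound 3 (beyond the scatter), so this position responds strongly to a small change in the chain. With isobutyl held constant, furan-3-yl in place of furan-2-yl on a saturated ring carbon gives a number 3 percentage points lower from compound 1 to compound 3 (within the scatter), so that change has no visible effect in this setting. Nothing at hand explains the drop.

From the compounds shown here alone, it remains open whether the furan change would matter with isopropyl on that oxygen. Also open, going by these compounds, is how an ethyl or methyl group would behave at this position.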